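From compound 2 to compound 3: one group removed

This account rests on a few compounds, and the source may have more. Where it says the series, first, only, none or still open, it means among the compounds named here.

In an ADME assay on tissue (MDA-MB-231 cells, Homo sapiens) for pharmacokinetics (a higher number here means that the compound lasts longer, a lower number that the compound disappears faster), compound 1 (`CC(C)[C@H](N)C(=O)OC[C@H]1O[C@@H](n2cc(F)c(=O)[nH]c2=O)C[C@@H]1O`) gives 0.255 h and compound 2 (`CC(C)[C@H](N)C(=O)OC[C@H]1O[C@@H](n2cc(F)c(=O)[nH]c2=O)C[C@@H]1OC(=O)[C@@H](N)C(C)C`) gives 0.168 h. Among the measured compounds shown here, compound 2 therefore stands within the scatter of the only other compound measured so far. Compound 3 (`CC(C)[C@H](N)C(=O)O[C@H]1C[C@H](n2cc(F)c(=O)[nH]c2=O)O[C@@H]1CO`) is still unmeasured and differs from compound 2 by hydrogen in place of (1-amino-2-methylpropyl)carbonyl on an oxygen on a saturated carbon, with hydrogen in place of (1-amino-2-methylpropyl)carbonyl on an oxygen on a saturated carbon. For the measured compounds named here, only one measured step bears on this change, and only indirectly, since it concerns the same group on another oxygen: a 1.5-fold lower number from compound 1 to compound 2 (0.18 log units; within the scatter). That step stays inside the scatter, so no step beyond the scatter is expected in this assay. The expected size is a 1.3-fold higher number from compound 2 to compound 3 (0.12 log units; within the scatter), with no firm direction. For compound 3 the estimated half-life is 0.22 h, with an expected range of 0.11 h to 0.45 h.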

Compound 3, half-life: 0.248 h
Beside the measured number, compound 3's estimate is 1.1-fold (0.05 log units) below it; low and high end bracket the measured number.
By their numbers in this assay, from the lowest: compounds 2, 3 and 1 (each within the scatter of the next).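

In this assay the loss of (1-amino-2-methylpropyl)carbonyl from the oxygen of the (((1-amino-2-methylpropyl)carbonyl)oxy)methyl group, which leaves hydroxymethyl, gives a 1.5-fold higher number from compound 2 to compound 3 (0.17 log units; within the scatter) and so stays inside the usual spread of repeats. Among the compounds shown here, until now the only reading of this group came from the other oxygen, with a 1.5-fold lower number from compound 1 to compound 2 (0.18 log units; within the scatter) as the step there. Compound 2 now has a measured step at each of its two esterified oxygens, and neither step can be told from the scatter. No measurement shown here offers an explanation for these half-lives.

The compounds shown leave open whether a different group on this oxygen, such as acetyl or a longer chain, would give a step beyond the scatter. They also leave open how the shared core reads with a free hydroxy on both oxygens.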